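The source may hold more compounds than are shown below. What is called first, only, known or untested is meant among the compounds shown, and "the series" means these compounds.

Three compounds have been measured in a functional assay on K562 cells (Homo sapiens) for cytotoxicity, read by MTT assay, with a stated time of 72 h (a higher number here means a weaker inhibitor, a lower number a stronger inhibitor), so far, with these results:

compound 1 `CCCCC(C)C[C@]1(CC)O[C@H]1[C@]1(CC)C=CC(=O)O1` gives > 50000 nM as a limit
compound 2 `CCCCC(C)C/C(=C/[C@@]1(CC)OC(=O)C[C@@H]1O)CC` gives 49200 nM as a number
compound 3 `CCCCC(C)Cc1cc(CC)c(CC(=O)O)o1` gives > 100000 nM as a limit

Compound 1 therefore has no exact value, only the limit > 50000 nM in this assay as its result. Compound 4 `CCCCC(CC)C[C@]1(CC)O[C@H]1[C@]1(CC)C=CC(=O)O1` has not yet been measured. It differs from compound 1 in one place, methyl in place of hydrogen on a saturated chain carbon, three bonds along the chain from a saturated ring carbon and so 1-methylpentyl becomes 1-ethylpentyl. Going by the values given here, no measured pair here differs in one place only, so the data show no direct precedent for this change. Among the compounds with values here, the only exact value comes from compound 2 at 49200 nM in this assay and offers no reason to expect a large shift. No change beyond the scatter is expected, in either direction, and the estimated a number no higher from compound 1 to compound 4 (the limit leaves the size open) is read in that light. A limit rather than a number is also quite likely for the new compound. Compound 4 is expected at 50000 nM with an estimated range from 20000 nM to 100000 nM when tested in this assay under the same conditions.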

Compound 4, half-maximal inhibitory concentration: > 100000 nM
Compound 4 ended at the assay's limit (the forecaster's own chance of this, stated with the estimate: 55%); middle value at least 2.0-fold (0.30 log units) from the limit.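

Compound 1 and compound 4 both stand only as limits in this assay, and no step can be read between them. The compounds shown leave open whether the change from 1-methylpentyl to 1-ethylpentyl shifts the half-maximal inhibitory concentration at all, and in which direction.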